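From compound 3 to compound 4: one added methyl

The source may report more compounds than this note shows. Statements on the series, on what has been measured and on what is new or still open speak of the compounds shown alone.

In a functional assay on MDA-MB-231 cells (Homo sapiens) for antiproliferative activity, read by MTT assay, with a stated time of 72 h (on this read-out higher numbers stand for weaker inhibition and lower numbers for stronger inhibition), compound 3 (`COc1ccc(/C=C/C(O)=C/C(=O)/C=C/c2ccc(OC)c(OC(=O)C(C)(CO)CO)c2)cc1O`) gives 2290 nM and lies within the scatter of both other measured compounds. These are compound 1 (`CCC(CO)(CO)C(=O)Oc1ccc(/C=C/C(=O)/C=C(O)/C=C/c2ccc(OC(=O)C(CC)(CO)CO)c(OC)c2)cc1OC`) at 2000 nM and compound 2 (`COc1ccc(/C=C/C(=O)/C=C(O)/C=C/c2ccc(OC)c(OC(=O)C(C)(CO)CO)c2)cc1OC(=O)C(C)(CO)CO`) at 4610 nM on the same read-out.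

Compound 4 (`CCC(CO)(CO)C(=O)Oc1cc(/C=C/C(=O)/C=C(O)/C=C/c2ccc(OC)c(O)c2)ccc1OC`) differs from compound 3 in one place (methyl in place of hydrogen on a saturated chain carbon, two bonds along the chain from a carbonyl carbon): methyl in place of hydrogen on a saturated chain carbon, two bonds along the chain from a carbonyl carbon. This turns (1,1-bis(hydroxymethyl)ethyl)carbonyl into (1,1-bis(hydroxymethyl)propyl)carbonyl.

Among the measured compounds shown here, no measured step covers this change directly. For the measured compounds named here, the one step available (a 2.0-fold lower number from compound 2 to compound 3 (0.30 log units; within the scatter)) puts hydrogen in place of the whole (1,1-bis(hydroxymethyl)ethyl)carbonyl on an oxygen on an aromatic ring, and it stays within the scatter. Compound 1 (2000 nM) carries (1,1-bis(hydroxymethyl)propyl)carbonyl but differs from compound 3 in more than one place, so it is only a loose guide.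

For the smaller change in this assay, no step beyond the scatter is expected and no direction can be assigned. The expected step (a 1.0-fold higher number from compound 3 to compound 4 (0.02 log units; within the scatter)) is accordingly within the scatter. The estimated value for compound 4 is 2400 nM with an expected range (1200 nM to 4800 nM).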

Compound 4, half-maximal inhibitory concentration: 3850 nM
Compound 4: middle estimate off by 1.6-fold (0.21 log units), on the low side, and the stated range covers the measured number.
By their numbers in this assay, from the lowest: compounds 1, 3, 4 and 2 (each within the scatter of the next, the first and the last beyond it).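

In this assay, methyl in place of hydrogen on a saturated chain carbon, two bonds along the chain from a carbonyl carbon, gives a 1.7-fold higher number from compound 3 to compound 4 (0.23 log units; within the scatter). Among the compounds shown here, this is the first single-place reading at that carbon, since the earlier step, a 2.0-fold lower number from compound 2 to compound 3 (0.30 log units; within the scatter), took away the whole (1,1-bis(hydroxymethyl)ethyl)carbonyl from an oxygen on an aromatic ring; on this read-out, (1,1-bis(hydroxymethyl)ethyl)carbonyl and (1,1-bis(hydroxymethyl)propyl)carbonyl are not told apart at this place, and neither single-place step lies beyond the scatter. No measurement in hand bears on the cause of this result.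

Still open, on these data alone, is whether any change at this carbon gives a step beyond the scatter, for instance a longer chain such as butyl in place of the ethyl, or an amine or a carboxylic acid carried on that chain. The compounds shown also leave open what happens when the hydroxymethyl groups themselves are replaced, for example by methoxymethyl, with the rest of compound 4 kept the same.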